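The compounds below may be only part of what the source reports. "The series", "measured", "known", "first", "only" and "open" are said of these compounds alone.

Going by the values given here, in a functional assay on NCI-H460 cells (Homo sapiens) for inhibition, read by sulforhodamine B assay, with a stated time of 48 h (a lower number here means a stronger inhibitor of growth, a higher number a weaker inhibitor of growth), compound 1 (`CCCCCCCCCCCC[C@@H](O)[C@H]1CC[C@H]([C@H](O)CCCCCCCCCCNC(=O)c2ccnn2C)O1`) gives 8130 nM and compound 2 (`CCCCCCCCCCCC[C@@H](O)[C@H]1CC[C@H]([C@H](O)CCCCCCCCCCN(C)C(=O)c2ccnn2C)O1`) gives 5500 nM so compound 2 stands within the scatter of the only other measured compound. Compound 3 (`CCCCCCCCCCCC[C@@H](O)[C@H]1CC[C@H]([C@H](O)CCCCCCCCCCNCc2ccnn2C)O1`) differs from compound 2 by one change (((1-methyl-1H-pyrazol-5-yl)methyl)amino in place of methyl((1-methyl-1H-pyrazol-5-yl)carbonyl)amino on a saturated chain carbon, ten or more bonds along the chain from an oxygen on a saturated carbon and a saturated ring carbon) on a saturated chain carbon. Among the compounds with values here, the one measured step that bears on it (a 1.5-fold lower number from compound 1 to compound 2 (0.17 log units; within the scatter)) is methyl in place of hydrogen on an amide-type nitrogen, and it leaves the carbonyl in place, so it says little about this change. The expected step in this assay (a 1.1-fold lower number from compound 2 to compound 3 (0.04 log units; within the scatter)) therefore has no firm direction and stays within the scatter. Compound 3 is estimated at 5000 nM (range 1600 nM to 15000 nM).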

Compound 3, concentration for 50% growth inhibition: 1700 nM
Compound 3: the middle estimate sits 2.9-fold (0.47 log units) above what was measured; the range from low to high includes it.
By their numbers in this assay, from the lowest: compound 3; then compounds 2 and 1 (each within the scatter of the next).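

Taking out the carbonyl does what adding a methyl to the amide nitrogen did not: in this assay, the number moves beyond the scatter. (1-methyl-1H-pyrazol-5-yl)methyl in place of (1-methyl-1H-pyrazol-5-yl)carbonyl on an amine nitrogen gives one such step (a 4.8-fold lower number from compound 1 to compound 3 (0.68 log units; beyond the scatter)), and the change from the methylated amide gives a similar one (a 3.2-fold lower number from compound 2 to compound 3 (0.51 log units; beyond the scatter)). No measurement shown explains these steps. Still open, from the compounds shown here alone, is whether a sulfonamide in place of the carbonyl, or a methyl on the amine nitrogen of compound 3, would move the number further.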